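Bromo in Place of Methyl: Expecting the Next Number

The compounds below may be only part of what the source reports. "The series", "measured", "known", "first", "only" and "open" are said of these compounds alone.

Of the compounds shown here, three on one shared core have been measured in a functional assay on T47D cells (Homo sapiens) for antiproliferative activity, read by CCK-8 assay, with a stated time of 72 h; on this read-out higher numbers stand for weaker inhibition and lower numbers for stronger inhibition. Compound 1 `Cc1nc2c(F)cc(-c3nc(Nc4ccc(NC(=O)C5(C(=O)Nc6ccc(F)cc6)CC5)cc4)ncc3F)cc2n1C(C)C` gives 25.5 nM. Compound 2 `Cc1nc2c(F)cc(-c3nc(Nc4ccc(NC(=O)C5(C(=O)Nc6cccc(F)c6)CC5)cc4)ncc3F)cc2n1C(C)C` gives 29.3 nM. Compound 3 `Cc1ccc(NC(=O)C2(C(=O)Nc3ccc(Nc4ncc(F)c(-c5cc(F)c6nc(C)n(C(C)C)c6c5)n4)cc3)CC2)cc1` gives 16 nM, the lowest of the three numbers, although the step of a 1.6-fold lower number from compound 1 to compound 3 (0.20 log units; within the scatter) and the step of a 1.8-fold lower number from compound 2 to compound 3 (0.26 log units; within the scatter) both fall within the scatter, so no order among the three can be claimed. The step of a 1.1-fold higher number from compound 1 to compound 2 (0.06 log units; within the scatter) likewise stays within the scatter.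

Compound 4 `Cc1nc2c(F)cc(-c3nc(Nc4ccc(NC(=O)C5(C(=O)Nc6ccc(Br)cc6)CC5)cc4)ncc3F)cc2n1C(C)C` has not yet been measured. It differs from compound 3 by bromo in place of methyl on an aromatic carbon, the change sitting on an aromatic carbon of a six-membered aromatic ring of carbon only, para to a large group. The measured steps that bear on this position are those that reach compound 3 from compound 1 and from compound 2: exchanging a fluorine-bearing phenyl for the methyl-bearing one moved the number by less than the scatter. Nothing measured here sets bromo apart from the groups already tried, so compound 4 is expected to show a step of a 1.3-fold higher number from compound 3 to compound 4 (0.10 log units; within the scatter) that remains within the scatter. Compound 4 is therefore estimated at 20 nM in this assay, with a range from 8 nM to 50 nM.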

Compound 4, half-maximal inhibitory concentration: 120 nM
Compound 4: middle estimate off by 6.0-fold (0.78 log units), on the low side, and the stated range ends below it.
By their numbers in this assay, from the lowest: compounds 3, 1 and 2 (each within the scatter of the next); then compound 4.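

In this assay, the group on the six-membered aromatic ring of carbon only, para to a large group, proves able to move the number beyond the scatter: bromo in place of methyl gives a 7.5-fold higher number from compound 3 to compound 4 (0.88 log units; beyond the scatter) and this is the largest of the new steps. Bromo in place of fluoro gives a 4.7-fold higher number from compound 1 to compound 4 (0.67 log units; beyond the scatter) and the exchange of 3-fluorophenyl for 4-bromophenyl gives a 4.1-fold higher number from compound 2 to compound 4 (0.61 log units; beyond the scatter) so compound 4 stands apart from all three earlier compounds, whose steps among themselves stayed within the scatter. Nothing shown here accounts for why bromo parts from methyl and fluoro at this place.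

The compounds shown leave open whether chloro, methoxy or a carboxylic acid at this place would stay with methyl and fluoro or fall with bromo, so the single bromo compound marks no trend across groups. Also open, from the compounds shown here alone, is whether the exchange of methyl for bromo would give a step of similar size on another core or in another cell line.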